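This account rests on a few compounds, and the source may have more. Where it says the series, first, only, none or still open, it means among the compounds named here.

Working notes on the series. Going by the values given here, in an ADME assay on KB cells (Homo sapiens) for cytotoxicity (a lower number here means that less compound is needed, a higher number that more compound is needed for the effect), compound 1 (`CCOC(=O)N1[C@@H]2C=C[C@@](OC)(C(=O)c3c2cc(OC)c(OC)c3OCc2ccc(F)cc2)N1C(=O)OCC`) gives 51.8 ug/mL as the only exact number so far. Compound 2 (`COc1cc2c(c(OC)c1OC)C(=O)[C@]1(OC)C=C[C@H]2N(C(=O)OCC(C)C)N1C(=O)OCC(C)C`) gives > 300 ug/mL as its reading, which is a limit of the assay and not a number. Compound 3 (`CCCCOc1c(OC)c(OC)cc2c1C(=O)[C@]1(OC)C=C[C@H]2N(C(=O)OCC(C)C)N1C(=O)OCC(C)C`) is compound 2 with propyl in place of hydrogen on a saturated chain carbon bound to an oxygen on an aromatic ring (methoxy to butoxy): propyl in place of hydrogen on a saturated chain carbon bound to an oxygen on an aromatic ring. Among the compounds with values here, no measured pair differs in one place only, so the size of this step in this assay remains a judgement. A modest move to a lower number is expected, and another reading at the limit remains quite possible. Within the data shown here, that expectation leans on compound 1 at 51.8 ug/mL as the only reading inside the range. The expected at least 2.3-fold lower number from compound 2 to compound 3 (0.36 log units; beyond the scatter) is small to moderate. For compound 3 the estimated value is 130 ug/mL with an expected range from 35 ug/mL to 400 ug/mL in this assay.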

Compound 3, concentration for half-maximal effect: 22.1 ug/mL
Beside the measured number, compound 3's estimate is 5.9-fold (0.77 log units) above it, outside the stated range (below it).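

In this assay, going by these compounds alone, methoxy to butoxy gives the first step that can be read for one change in one place: an at least 13-fold lower number from compound 2 to compound 3 (1.13 log units; beyond the scatter). Compound 2 reads > 300 ug/mL, which is a limit of the assay and not a number, and the step is therefore a bound and not an exact size: the limit of > 300 ug/mL in this assay, at which 1 of the 3 values shown sits. Adding propyl at this saturated chain carbon thus brings the reading inside the range of the assay, so this position responds to the change, which no earlier comparison could show.

On these data alone, what a longer chain such as hexyloxy, or a butoxy chain ending in an amine, would give at this place remains open. Also open, as far as these compounds go, is whether the same change would give a step of similar size on the core of compound 1.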